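Cyanosulfanyl in place of chloro on the chloromethyl arm

The source may report more compounds than this note shows. Statements on the series, on what has been measured and on what is new or still open speak of the compounds shown alone.

The series shares one core, carried by compound 1 `CCOC(=O)c1ccc(-c2noc(CO)n2)cc1`, compound 2 `COC(=O)c1ccc(-c2noc(CCl)n2)cc1` and compound 3 `O=C(O)c1ccc(-c2noc(CCl)n2)cc1`. In an ADME assay on MT2 cells (Homo sapiens) for cytotoxicity, read by XTT assay, with a stated time of 4 days (a lower number here means that less compound is tolerated, a higher number that more compound is tolerated), compound 1 gives 385000 nM, compound 2 gives 14200 nM and compound 3 gives 64000 nM. Among the compounds with values here, compound 2 holds the lowest of the three numbers; its nearest neighbour is compound 3, and the only one-place step recorded is a 4.5-fold higher number from compound 2 to compound 3 (0.65 log units; beyond the scatter). The unmeasured compound 4 `COC(=O)c1ccc(-c2noc(CSC#N)n2)cc1` differs from compound 2 in one place: cyanosulfanyl in place of chloro on a saturated chain carbon bound to an aromatic carbon. Within the data shown here, no measured step touches the saturated chain carbon bound to an aromatic carbon; the recorded step concerns hydrogen in place of methyl on an oxygen next to a carbonyl group, so it carries little weight for this change. Among the measured compounds shown here, with no direct precedent, no step beyond the scatter is expected in this assay, and the number for compound 4 is estimated to sit close to that of compound 2, the expected step being a 1.4-fold higher number from compound 2 to compound 4 (0.15 log units; within the scatter). Compound 4 is therefore estimated at 20000 nM, with a range from 7000 nM to 60000 nM.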

Compound 4, half-maximal cytotoxic concentration: 43700 nM
For compound 4 the middle estimate is 2.2-fold (0.34 log units) below the measured one, and the stated range covers the measured number.
By their numbers in this assay, from the lowest: compound 2; then compounds 4 and 3 (each within the scatter of the next); then compound 1.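

In this assay, the saturated chain carbon bound to an aromatic carbon now has a one-place step of its own: cyanosulfanyl in place of chloro gives a 3.1-fold higher number from compound 2 to compound 4 (0.49 log units; beyond the scatter). Within the data shown here, the earlier compounds offered no such reading, since their only one-place step, a 4.5-fold higher number from compound 2 to compound 3 (0.65 log units; beyond the scatter), lies elsewhere on the molecule. Both steps lead upward from compound 2, so the chloromethyl arm and the other end of the molecule can each shift this number beyond the scatter, though the data on hand give no measured explanation for either step.

From the compounds shown here alone, whether an amine or a methylsulfanyl group on the same carbon would shift the number in the same direction remains open. Also open, going by these compounds, is whether the cyanosulfanyl step would hold on the carboxylic acid of compound 3.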